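Compound 4: a new aromatic group on the shared core

The source may hold more compounds than are shown below. What is called first, only, known or untested is meant among the compounds shown, and "the series" means these compounds.

In a functional assay on HepG2 cells (Homo sapiens) for inhibition, read by MTT assay, with a stated time of 24 h (on this read-out higher numbers stand for weaker inhibition and lower numbers for stronger inhibition), compound 1 (`CC1(C)[C@H]2CC[C@]1(C)N(Cc1cn(-c3cccc(F)c3)nn1)C(=O)C2`) gives 80 nM, compound 2 (`CC1(C)[C@H]2CC[C@]1(C)N(Cc1cn(-c3ccc(C#N)cc3)nn1)C(=O)C2`) gives 50 nM and compound 3 (`CC1(C)[C@H]2CC[C@]1(C)N(Cc1cn(-c3ccc(Br)cc3)nn1)C(=O)C2`) gives 110 nM. The number for compound 3 is the highest of the three, but only one gap to it exceeds the scatter. That gap is a 2.2-fold higher number from compound 2 to compound 3 (0.34 log units; beyond the scatter), whereas the other is a 1.4-fold higher number from compound 1 to compound 3 (0.14 log units; within the scatter).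

Compound 4 (`Cc1ccccc1-n1cc(CN2C(=O)C[C@@H]3CC[C@@]2(C)C3(C)C)nn1`) has 2-methylphenyl in place of 4-bromophenyl on an aromatic nitrogen. Going by the values given here, no measured compound carries 2-methylphenyl, so the evidence is indirect. It comes from the exchanges of the aromatic group at this same place, the third being a 1.6-fold lower number from compound 1 to compound 2 (0.20 log units; within the scatter). Of these three steps, two stay within the scatter and one is modest, so no step beyond the scatter is expected in this assay, and no direction is favoured. The expected change is a 1.1-fold lower number from compound 3 to compound 4 (0.04 log units; within the scatter). The estimate for compound 4 is 100 nM, with an expected range of 45 nM to 220 nM.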

Compound 4, half-maximal inhibitory concentration: 150 nM
Beside the measured number, compound 4's estimate is 1.5-fold (0.18 log units) below it; measured number inside the range.
By their numbers in this assay, from the lowest: compounds 2, 1, 3 and 4 (each within the scatter of the next, the first and the last beyond it).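

In this assay, 2-methylphenyl on this aromatic nitrogen stays close to two of the earlier aromatic groups, with a 1.4-fold higher number from compound 3 to compound 4 (0.13 log units; within the scatter) and a 1.9-fold higher number from compound 1 to compound 4 (0.27 log units; within the scatter). Going by these compounds alone, only the exchange with 4-cyanophenyl goes beyond the scatter, at a 3.0-fold higher number from compound 2 to compound 4 (0.48 log units; beyond the scatter), so a methyl-bearing phenyl joins the series without a clear separation from the fluoro and bromo compounds, and compound 2 is the only one set apart from compound 4. Nothing available on these compounds gives a reason for these differences.

Going by these compounds, all four groups at this place are substituted phenyl rings, so the reading of an unsubstituted phenyl, a cyclohexyl ring or a phenyl bearing a carboxylic acid or an amine remains open. The compounds shown also vary nothing but this group, leaving open how a longer chain between the shared core and the five-membered ring would read.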